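The source may report more compounds than this note shows. Statements on the series, on what has been measured and on what is new or still open speak of the compounds shown alone.

Compound 1 `CCCn1c(-c2ccc(OC)cc2)cnc1NC(=O)c1ccc(F)cc1`: in a toxicity assay on THP-1 cells (Homo sapiens) for inhibition (on this read-out higher numbers stand for lower toxicity in this test and lower numbers for higher toxicity in this test), compound 1 gives > 100000 nM, a limit of the assay.
Compound 2 `COc1ccc(-c2cnc(NC(=O)c3ccc(F)cc3)n2-c2ccccc2)cc1`: in this assay compound 2 gives 8800 nM.
Compound 3 `CCn1c(-c2ccc(OC)cc2)cnc1NC(=O)c1ccc(F)cc1`: in this assay compound 3 gives > 100000 nM, again a limit.

Compound 3 thus sits at the limit (the limit of > 100000 nM in this assay, at which 2 of the 3 values shown sit), with only compound 2 giving a number. Compound 4 `COc1ccc(-c2cnc(NC(=O)c3ccc(F)cc3)n2C2CCCC2)cc1` differs from compound 3 by cyclopentyl in place of ethyl on an aromatic nitrogen. For the measured compounds named here, two measured steps concern the group on this aromatic nitrogen: an at least 11-fold lower number from compound 1 to compound 2 (1.05 log units; beyond the scatter) and an at least 11-fold higher number from compound 2 to compound 3 (1.05 log units; beyond the scatter), both large. A ring entering in place of ethyl points in the same direction as the phenyl of compound 2, so a lower number is expected, though a smaller shift than with phenyl. For compound 4 the expected step is an at least 2.5-fold lower number from compound 3 to compound 4 (0.39 log units; beyond the scatter). Compound 4 is estimated at 40000 nM, between 10000 nM and 150000 nM.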

Compound 4, half-maximal cytotoxic concentration: > 100000 nM
Compound 4 gave a limit, no number (the forecaster's own chance of this, stated with the estimate: 40%); middle value at least 2.5-fold (0.39 log units) away from the limit.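

Cyclopentyl does not act like the phenyl of compound 2 at this aromatic nitrogen: the change gives an at least 11-fold higher number from compound 2 to compound 4 (1.05 log units; beyond the scatter). Bringing a ring onto this nitrogen is therefore not enough to give a number, and among the groups shown only phenyl does so, while propyl, ethyl and cyclopentyl all end at the limit: the limit of > 100000 nM in this assay, at which 3 of the 4 values shown sit. The steps from compound 3 to compound 4 and from compound 1 to compound 4 join two limits and cannot be read.

On these data alone, how compound 1, compound 3 and compound 4 rank among themselves stays open. So does whether a benzyl group or a pyridyl ring on this nitrogen would give a number, as phenyl does.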